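The source may report more compounds than this note shows. Statements on the series, on what has been measured and on what is new or still open speak of the compounds shown alone.

Measured so far:
- compound 1, `CN1CCC(CNS(=O)(=O)c2ccccc2Nc2cc(-c3ccc4ccn(C)c4c3)c3nccnc3c2)C1` — 11 nM
- compound 2, `Cn1cc(CNC(=O)c2ccncc2Nc2cc(-c3ccc4ccn(C)c4c3)c3nccnc3c2)cn1` — 159 nM

In an assay for inhibition of 6-phosphofructo-2-kinase/fructose-2,6-bisphosphatase 3 (Homo sapiens), read by ADP-Glo, with a stated time of 2 h (a higher number here means a weaker inhibitor, a lower number a stronger inhibitor), compound 1 gives 11 nM and compound 2 gives 159 nM. Compound 2 thus holds the higher of the two numbers, and the gap to compound 1 lies well beyond the scatter; the two structures differ in several places at once, so nothing is known about which of them carries that gap.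

Compound 3, `Cn1ccc2ccc(-c3cc(Nc4cnccc4C(=O)NCC4COCCN4)cc4nccnc34)cc21`, is not yet measured. It differs from compound 2 in one place: morpholin-3-yl in place of 1-methyl-1H-pyrazol-4-yl on a saturated chain carbon bound to an amide-type nitrogen. Among the measured compounds shown here, no step between measured compounds isolates this change, so its size cannot be read from the data. The expectation is a step from compound 2 to compound 3 of a 1.3-fold lower number from compound 2 to compound 3 (0.12 log units; within the scatter) in this assay, small and uncertain in direction, not clearly beyond the scatter. For compound 3 the estimate in this assay is 120 nM, with a range from 40 nM to 400 nM.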

Compound 3, half-maximal inhibitory concentration: 33 nM
The estimate for compound 3 lay 3.6-fold (0.56 log units) above the measured number; measured number below the stated range.
By their numbers in this assay, from the lowest: compound 1; then compound 3; then compound 2.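

In this assay, the group on a saturated chain carbon bound to an amide-type nitrogen proves able to move the number beyond the scatter: morpholin-3-yl in place of 1-methyl-1H-pyrazol-4-yl gives a 4.8-fold lower number from compound 2 to compound 3 (0.68 log units; beyond the scatter) with the rest of the structure unchanged. The two groups have equal heavy-atom counts, but they differ in ring size and aromaticity, and the entering ring carries a hydrogen-bond donor that the leaving ring lacks, so this single step changes several features together. No available measurement explains the step or assigns it to any one of these features.

From the compounds shown here alone, whether the lower number follows the ring nitrogen, the ring oxygen or the saturated six-membered ring remains open. Tetrahydropyran-3-yl, piperidin-3-yl or 4-methylmorpholin-3-yl on the same chain carbon would help separate these features.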